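A few compounds are considered here, and "the series" means these few. Any claim that something is new, unique, unknown or untested is made for them only; others in the source may bear on it.

Measured compounds:
compound 1 `COc1ncc(-c2ccc3c(c2)N(c2ccc(C)cc2)C(=O)CO3)cc1NS(=O)(=O)c1ccc(F)cc1` — 28300 nM
compound 2 `O=C1COc2ccc(-c3cnc4ccccc4c3)cc2N1` — 26300 nM

In a functional assay on HepG2 cells (Homo sapiens) for antiproliferative activity, read by MTT assay, with a stated time of 72 h (a lower number here means a stronger inhibitor, a higher number a weaker inhibitor), compound 1 gives 28300 nM, the higher of the two numbers recorded; compound 2 gives 26300 nM, and the gap between the two lies within the scatter of repeated measurements, so neither can be called the stronger inhibitor. Going by the values given here, both numbers are high, and the series so far shows only weak activity in this assay.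

Compound 3 `COc1ncc(-c2ccc3c(c2)N(c2ccc(F)cc2)C(=O)CO3)cc1NS(=O)(=O)c1ccc(F)cc1` has not yet been measured in this assay. Relative to compound 1 the change is: fluoro in place of methyl on an aromatic carbon. Among the compounds with values here, no pair of measured compounds isolates this change, so its effect cannot be read from the data. With compound 1 at 28300 nM as the only reference, a step from compound 1 to compound 3 no larger than the scatter is expected, in no fixed direction. The expected step, a 1.1-fold lower number from compound 1 to compound 3 (0.05 log units; within the scatter), is therefore small. Compound 3 is estimated at 25000 nM, with a range from 10000 nM to 60000 nM.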

Compound 3, half-maximal inhibitory concentration: 36400 nM
Estimate against measurement, compound 3: 1.5-fold (0.16 log units) below; the range from low to high includes it.
By their numbers in this assay, from the lowest: compounds 2, 1 and 3 (each within the scatter of the next).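

In this assay, the exchange of 4-methylphenyl for 4-fluorophenyl gives a 1.3-fold higher number from compound 1 to compound 3 (0.11 log units; within the scatter). Going by these compounds alone, this is the only step that isolates a single place, and it shows that methyl and fluoro cannot be told apart at this position: both compounds remain in the same weak range. No data on hand bear on why the two groups read alike.

On these data alone, one exchange at one position says little about how far this site can respond, so it remains open whether an amine or a carboxylic acid in place of the fluoro would move the number beyond the scatter. Within the data shown here, also open is whether any single change elsewhere on the shared core would do so, since the series so far offers no step there.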